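Ethoxy to methoxy in a free fatty acid receptor agonist

The source may report more compounds than this note shows. Statements on the series, on what has been measured and on what is new or still open speak of the compounds shown alone.

Among the measured compounds shown here, compound 1, `CCOc1cc(C)c(-c2cccc(COc3ccc(OCC(=O)O)c(F)c3)c2)c(C)c1`, is the only member of this small group with a number to its name. In a functional assay on CHO cells for agonist activity at Free fatty acid receptor 1 (Homo sapiens), read by FLIPR and calcium flux (on this read-out lower numbers stand for an effect already at smaller amounts and higher numbers for an effect only at larger amounts of compound), compound 1 gives 65.9 nM. Two related compounds were also in the study: compound 2, `CC(=O)N(CC(=O)O)c1ccc(OCc2cccc(-c3c(C)cc(OCCCS(C)(=O)=O)cc3C)c2)cc1`, and compound 3, `Cc1cc(OCCCS(C)(=O)=O)cc(C)c1-c1cccc(COc2ccc(N(CC(=O)O)C(=O)c3ccccc3)cc2)c1`. Neither carries a result, for compound 2 the entry in this assay stands as "not determined" (no result reported), and for compound 3 it stands as "not determined" (no result reported), so nothing can be said about where either of them stands relative to compound 1.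

Compound 4, `COc1cc(C)c(-c2cccc(COc3ccc(OCC(=O)O)c(F)c3)c2)c(C)c1`, differs from compound 1 in a single place: hydrogen in place of methyl on a saturated chain carbon bound to an oxygen on an aromatic ring, or ethoxy to methoxy when the cut is made one bond further out. For the measured compounds named here, no pair of measured compounds shows this change, so there is no measured step to lean on.

With a change this small at the far end of the molecule, the step is expected to stay within or only slightly beyond the usual scatter, and if anything to lean toward an effect only at somewhat larger amounts. Compound 4 is therefore expected to give 95 nM, with a likely range from 35 nM to 260 nM, which means an estimated step of a 1.4-fold higher number from compound 1 to compound 4 (0.16 log units; within the scatter).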

Compound 4, half-maximal effective concentration: 49.7 nM
Beside the measured number, compound 4's estimate is 1.9-fold (0.28 log units) above it, and the stated range covers the measured number.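

In this assay, among the compounds shown here, going from ethoxy to methoxy gives a 1.3-fold lower number from compound 1 to compound 4 (0.12 log units; within the scatter) and so provides the first measured step at this position. Hydrogen in place of methyl on a saturated chain carbon bound to an oxygen on an aromatic ring therefore leaves the two compounds indistinguishable on this read-out, and the outer methyl of the ethoxy group is shown to be removable without a change that can be told from the scatter. Nothing available explains this result or connects it to any property of the group.

This single pair leaves open whether the same tolerance holds in other settings, since it describes the change only on the core of compound 1 with its fluorine-bearing acid part. It also leaves open how far the position can be varied in the other direction, whether with a longer chain such as propoxy, a branched chain such as isopropoxy, or a chain ending in an amine or a carboxylic acid, any of which might move the number beyond the scatter.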